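A few compounds are considered here, and "the series" means these few. Any claim that something is new, unique, unknown or untested is made for them only; others in the source may bear on it.

- compound 1 `COC(CSc1ccccc1)CN1CCN(CCCC(c2ccc(F)cc2)c2ccc(F)cc2)CC1` gives 20000 nM in the whole-brain test below
- compound 2 `CC(=O)N(CC(O)CN1CCN(CCCC(c2ccc(F)cc2)c2ccc(F)cc2)CC1)c1ccccc1` gives 390000 nM in the same test

Compound 1 holds the lower of the two numbers in a functional assay (brain) with Canis familiaris (Canis lupus familiaris) as the target (a higher number here means a weaker inhibitor, a lower number a stronger inhibitor), and is the stronger inhibitor of the pair. Compound 3 `OC(CNCc1ccccc1)CN1CCN(CCCC(c2ccc(F)cc2)c2ccc(F)cc2)CC1`, not yet measured, carries 2-(benzylamino)-1-hydroxyethyl in place of 1-methoxy-2-(phenylsulfanyl)ethyl on a saturated chain carbon bound to an amine nitrogen in a ring. Within the data shown here, no measured step isolates this change. Compound 2, which also bears a hydroxy group on its chain, stands at 390000 nM and so points to a rise in the number. The expected step is a 3.0-fold higher number from compound 1 to compound 3 (0.48 log units; beyond the scatter) and would lie beyond the scatter. For compound 3 the estimated value is 60000 nM with an expected range from 15000 nM to 250000 nM overall.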

Compound 3, half-maximal inhibitory concentration: 6900 nM
Estimate against measurement, compound 3: 8.7-fold (0.94 log units) above; the whole stated range lies above it.
By their numbers in this assay, from the lowest: compound 3; then compound 1; then compound 2.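

In this assay, a hydroxy group on the chain does not by itself bring a high number: 2-(benzylamino)-1-hydroxyethyl in place of 1-methoxy-2-(phenylsulfanyl)ethyl gives a modest drop (a 2.9-fold lower number from compound 1 to compound 3 (0.46 log units; beyond the scatter)). With the hydroxy group kept, benzylamino in place of acetyl(phenyl)amino gives a far larger drop (a 57-fold lower number from compound 2 to compound 3 (1.75 log units; beyond the scatter)), so the group at the chain end matters greatly between these two compounds. Nothing available here accounts for either step. From the compounds shown here alone, the change from compound 1 alters the hydroxy group and the benzylamino group together, so their separate shares stay open. Going by these compounds, whether a phenethylamino group or a benzyloxy group at the chain end would keep the number of compound 3 also stays open.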